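Methoxycarbonyl for ethyl: compound 2 to compound 3

A few compounds are considered here, and "the series" means these few. Any claim that something is new, unique, unknown or untested is made for them only; others in the source may bear on it.

In an ADME assay on HCT-116 cells (Homo sapiens) for cytotoxicity, read by CellTiter-Glo, with a stated time of 72 h (a higher number here means a weaker inhibitor, a lower number a stronger inhibitor), compound 1 (`COc1cccc(S(=O)(=O)N2CCC(N3CCC(C)CC3)CC2)c1`) gives > 5000 nM, which is a limit of the assay and not a number. Compound 2 (`CCc1ccc(S(=O)(=O)N2CCC(N3CCC(C)CC3)CC2)cc1`) gives > 5000 nM, which is likewise only a limit. Compound 2 therefore has no number to stand on, and the whole picture so far is the limit of > 5000 nM in this assay, at which 2 of the 2 values shown sit.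

Compound 3 (`COC(=O)c1ccc(S(=O)(=O)N2CCC(N3CCC(C)CC3)CC2)cc1`) has methoxycarbonyl in place of ethyl on an aromatic carbon, para to a large group: methoxycarbonyl in place of ethyl on an aromatic carbon.

Within the data shown here, only one measured step bears on this change: a step that the two limits leave unreadable from compound 1 to compound 2. It has no readable size, so no size can be carried over from it. It does show a change of aryl substituent on the shared core with both compounds at the same limit. On that slim basis, no step beyond the scatter is expected in this assay, and no direction can be assigned. The expected step, as an estimate, is a step that the limit leaves unreadable from compound 2 to compound 3. Compound 3 is most likely to be reported as a limit as well. For compound 3 the estimated value is 8000 nM, with an expected range of 5000 nM to 20000 nM.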

Compound 3, half-maximal inhibitory concentration: > 5000 nM
Compound 3: no number, only a limit; the forecaster's own chance of this, stated with the estimate: 85%; the middle value is on the limit's open side.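

Compound 2 and compound 3 both stand only at a limit in this assay, and a limit is not a number, so no step can be read between them. The compounds shown leave open how far any of them lies from that limit, and whether any substituent on the aromatic ring shifts the value: the limit of > 5000 nM in this assay, at which 3 of the 3 values shown sit.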